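Homologation of the Benzamide in a Piperidine Chemokine Antagonist Series

The compounds below may be only part of what the source reports. "The series", "measured", "known", "first", "only" and "open" are said of these compounds alone.

Measured compounds:
Compound 1, `CC(C)C(NC(=O)c1ccccc1)C(=O)N1CCN(c2ccc(Cl)cc2)CC1`, 525 nM
Compound 2, `Cc1ccccc1C(=O)N[C@@H](C(=O)N1CCC(c2ccc(Cl)cc2)CC1)C(C)C`, 32 nM
Compound 3, `CCCC(NC(=O)c1ccccc1C)C(=O)N1CCC(c2ccc(Cl)cc2)CC1`, 152 nM

Of the compounds shown here, three have been measured in an assay on THP-1 cells for displacement of a labelled ligand from C-C chemokine receptor type 1 (Homo sapiens); a lower number here means a stronger inhibitor, a higher number a weaker inhibitor. Compound 2 stands lowest of the three numbers, with compound 3 next and compound 1 furthest away; both gaps lie beyond the usual scatter, so compound 2 is the strongest inhibitor of the group. Compound 4, `Cc1ccccc1CCC(=O)N[C@@H](C(=O)N1CCC(c2ccc(Cl)cc2)CC1)C(C)C`, has not yet been measured in this assay. It differs from compound 2 in one place: 2-(2-methylphenyl)ethyl in place of 2-methylphenyl on a carbonyl carbon. The amide nitrogen, the valine-derived centre and the chlorophenyl piperidine are kept, so the change is the insertion of a two-carbon link between the carbonyl and the aromatic ring. For the measured compounds named here, no measured pair shows this kind of lengthening, so the direction rests on the measured compounds alone. The author expects a moderate loss of binding, a step of a 4.7-fold higher number from compound 2 to compound 4 (0.67 log units; beyond the scatter) that goes beyond the scatter. Compound 4 is therefore estimated at 150 nM, with a plausible range from 40 nM to 600 nM.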

Compound 4, half-maximal inhibitory concentration: 19 nM
Compound 4: the middle estimate sits 7.9-fold (0.90 log units) above what was measured, outside the stated range (below it).
By their numbers in this assay, from the lowest: compounds 4 and 2 (each within the scatter of the next); then compound 3; then compound 1.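

Replacing 2-methylphenyl with 2-(2-methylphenyl)ethyl on the carbonyl carbon gives a 1.7-fold lower number from compound 2 to compound 4 (0.23 log units; within the scatter) in this assay, so the two compounds cannot be separated in this measurement. This position therefore accepts the longer group with no change beyond the scatter, and the aromatic ring need not be attached directly to the carbonyl carbon for the binding seen with compound 2 to be kept. No independent evidence accounts for this tolerance.

The compounds shown leave open how far the link can be varied, including whether a single methylene link or a longer chain would be accepted on the same carbonyl carbon. They also leave open whether the ring methyl matters in the lengthened group, as an unsubstituted 2-phenylethyl group would show, and whether an amine or a carboxylic acid would be accepted on the chain.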